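The source may hold more compounds than are shown below. What is called first, only, known or untested is meant among the compounds shown, and "the series" means these compounds.

Working notes on the series. Compound 1 is `C=CC1=C(C(=O)Nc2ccccc2OC)C(c2ccc(F)cc2)OC1`. In a functional assay on SW480 cells (Homo sapiens) for cytotoxicity, read by MTT assay, with a stated time of 24 h (a lower number here means a stronger inhibitor, a higher number a weaker inhibitor), compound 1 gives only a limit, > 100000 nM. Compound 2, `C=CC1=C(C(=O)Nc2ccccc2OC)C(c2ccc(OC)cc2)OC1`, carries methoxy in place of fluoro on an aromatic carbon. In this assay compound 2 also returns a limit, > 100000 nM. Compound 3, `C=CC1=C(C(=O)Nc2ccccc2OC)C(c2ccc(Cl)c(Cl)c2)OC1`, has 3,4-dichlorophenyl in place of 4-fluorophenyl on a saturated ring carbon. In this assay compound 3 likewise stops at a limit, > 100000 nM. The steps a step that the two limits leave unreadable from compound 1 to compound 2, a step that the two limits leave unreadable from compound 1 to compound 3 and a step that the two limits leave unreadable from compound 2 to compound 3 give no readable size, since all three values sit at the limit of > 100000 nM in this assay, at which 3 of the 3 values shown sit. Compound 1 thus stands at that limit, with no number to set it against the other two, and the changes on the aromatic ring and on the saturated ring carbon have left nothing measurable.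

Compound 4, `C=CC1=C(C(=O)NCCCCC)C(c2ccc(F)cc2)OC1`, is the next candidate. It differs from compound 1 in one place: pentyl in place of 2-methoxyphenyl on an amide-type nitrogen. Among the measured compounds shown here, none of the measured steps touches the amide-type nitrogen; no measured step bears on this change, and the three that exist read only as limits. A limit is therefore the likeliest outcome again, and the step from compound 1 to compound 4 is expected as a number no higher from compound 1 to compound 4 (the limit leaves the size open). Compound 4 is expected at 100000 nM, within 30000 nM to 300000 nM.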

Compound 4, half-maximal inhibitory concentration: > 100000 nM
Compound 4 gave a limit, no number (the forecaster's own chance of this, stated with the estimate: 80%); the middle value sits exactly at the limit.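

In this assay compound 4 gives only a limit, > 100000 nM, so the step from compound 1 to compound 4 has no readable size, and the series remains without a number: the limit of > 100000 nM in this assay, at which 4 of the 4 values shown sit.

The compounds shown leave open whether any change on the aromatic carbon, the saturated ring carbon or the amide-type nitrogen affects cytotoxicity, and how these compounds would rank.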